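One Group Exchanged on the Carbonyl Carbon

This account rests on a few compounds, and the source may have more. Where it says the series, first, only, none or still open, it means among the compounds named here.

In a functional assay on A2780 cells (Homo sapiens) for inhibition, read by sulforhodamine B assay, with a stated time of 72 h (on this read-out lower numbers stand for stronger inhibition and higher numbers for weaker inhibition), compound 1 (`Cn1c(C(=O)NCc2ccc(S(=O)(=O)c3ccccc3)cc2)cc2ccncc21`) returns > 10000 nM as a limit and not a number. In this assay, going by the values given here, compound 2 (`O=C(NCc1ccc(S(=O)(=O)N2CCCCC2)cc1)c1cc2ccncc2[nH]1`) gives 1700 nM as the only actual number so far. Compound 3 (`O=C(NCc1ccc(S(=O)(=O)N2CCCCC2)cc1)c1cc2ccncc2o1`) has not been measured and differs from compound 2 on a carbonyl carbon: a group of 9 heavy atoms (7 carbon, 1 nitrogen, 1 oxygen; one five-membered aromatic ring with 1 hetero atom, one six-membered aromatic ring with 1 hetero atom) in place of a group of 9 heavy atoms (7 carbon, 2 nitrogen; one five-membered aromatic ring with 1 hetero atom, one six-membered aromatic ring with 1 hetero atom), on a carbonyl carbon is the whole change. Among the compounds with values here, no measured step bears directly on this exchange, so a moderate shift toward stronger inhibition in this assay is expected only tentatively, and a 2.4-fold lower number from compound 2 to compound 3 (0.39 log units; beyond the scatter) is the estimated step. For compound 3 the estimated value is 700 nM with an expected range from 100 nM to 5000 nM in this test.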

Compound 3, half-maximal inhibitory concentration: 29 nM
Estimate against measurement, compound 3: 24-fold (1.38 log units) above, and the stated range ends above it.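

In this assay, going by these compounds alone, the exchange on the carbonyl carbon gives a 59-fold lower number from compound 2 to compound 3 (1.77 log units; beyond the scatter), the first step that can be read here, and it shows that this place responds strongly to a change of a single ring atom. The group that enters has 0 hydrogen-bond donors and 2 hydrogen-bond acceptors, while the group that leaves has 1 of each. No measurement shown accounts for the size of this step. From the compounds shown here alone, whether the loss of the donor or the gain of the oxygen matters more remains open. So does the effect of a sulfur atom in that five-membered aromatic ring.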